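Trifluoromethyl in Place of Cyano on the Shared Core

The source may hold more compounds than are shown below. What is called first, only, known or untested is meant among the compounds shown, and "the series" means these compounds.

For the measured compounds named here, compound 1 `N#Cc1c(N2CCC(c3ccccc3)CC2)ccn(CC2CC2)c1=O` gives 151 nM in a functional assay on CHO cells for positive allosteric modulation of metabotropic glutamate receptor 2 (Homo sapiens), with a stated time of 30 min (a lower number here means that less compound is needed, a higher number that more compound is needed for the effect), the lowest of the two numbers measured so far. Compound 2 `N#Cc1c(N2CCC(c3ccccc3)CC2)ccn(CCCC(F)(F)F)c1=O` gives 355 nM, and the step of a 2.4-fold higher number from compound 1 to compound 2 (0.37 log units; beyond the scatter) alters only the chain on the ring nitrogen. Compound 3 `O=c1c(C(F)(F)F)c(N2CCC(c3ccccc3)CC2)ccn1CC1CC1` differs from compound 1 at another place: trifluoromethyl in place of cyano on an aromatic carbon. Going by the values given here, the single measured step concerns a different position, so no measured step bears directly on this change, and the direction cannot be read from the data. Compound 3 is expected to give 300 nM, within a range of 80 nM to 1200 nM. That expectation corresponds to an estimated step of a 2.0-fold higher number from compound 1 to compound 3 (0.30 log units; within the scatter).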

Compound 3, half-maximal effective concentration: 251 nM
Compound 3: the middle estimate sits 1.2-fold (0.08 log units) above what was measured, and the stated range covers the measured number.
By their numbers in this assay, from the lowest: compounds 1, 3 and 2 (each within the scatter of the next, the first and the last beyond it).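

At this aromatic carbon, trifluoromethyl in place of cyano leaves the number in this assay within the usual scatter: a 1.7-fold higher number from compound 1 to compound 3 (0.22 log units; within the scatter). The measured numbers therefore do not separate the two groups at this place, although the nitrile's hydrogen-bond acceptor is gone in compound 3. No measurement on hand explains this result.

Going by these compounds, what an amine or a carboxylic acid would give on this aromatic carbon stays open. So does whether trifluoromethyl here would fare the same with the chain of compound 2 on the ring nitrogen.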